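From 4-chlorophenyl to 4-bromophenyl: an expected small step

This account rests on a few compounds, and the source may have more. Where it says the series, first, only, none or still open, it means among the compounds named here.

- Compound 1 `O=[N+]([O-])c1ccc2[nH]c(CSCc3nc4cc([N+](=O)[O-])ccc4[nH]3)nc2c1`: 2410 nM
- Compound 2 `O=C(CSCc1nc2cc([N+](=O)[O-])ccc2[nH]1)c1ccccc1`: 12400 nM
- Compound 3 `O=C(CSCc1nc2cc([N+](=O)[O-])ccc2[nH]1)c1ccc(Cl)cc1`: 2230 nM

In a functional assay on HCT-116 cells (Homo sapiens) for cytotoxicity, read by MTT assay, with a stated time of 48 h (on this read-out lower numbers stand for stronger inhibition and higher numbers for weaker inhibition), compound 3 gives 2230 nM, which stands level with compound 1 within the usual scatter and clearly apart from compound 2. Within the data shown here, only one measured step bears on the position in question: a 5.6-fold lower number from compound 2 to compound 3 (0.75 log units; beyond the scatter), a modest change beyond the scatter in which chloro replaced hydrogen. Compound 4 `O=C(CSCc1nc2cc([N+](=O)[O-])ccc2[nH]1)c1ccc(Br)cc1` alters that same position once more: bromo in place of chloro on an aromatic carbon, para to a large group. Among the measured compounds shown here, the earlier step began from hydrogen, whereas this one exchanges one halogen for another, and no bromo compound has yet been measured. The size of the earlier step therefore does not carry over, and no step beyond the scatter is expected in this assay. The estimated change is a 1.1-fold lower number from compound 3 to compound 4 (0.03 log units; within the scatter). For compound 4 the expected value is 2100 nM, with an estimated range from 1000 nM to 4500 nM.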

Compound 4, half-maximal inhibitory concentration: 1780 nM
For compound 4 the middle estimate is 1.2-fold (0.07 log units) above the measured one, within the range that was stated.
By their numbers in this assay, from the lowest: compounds 4, 3 and 1 (each within the scatter of the next); then compound 2.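

In this assay the position accepts a second halogen with no step beyond the scatter, as a 1.3-fold lower number from compound 3 to compound 4 (0.10 log units; within the scatter) shows. Set against hydrogen at the same place, bromo gives a 7.0-fold lower number from compound 2 to compound 4 (0.84 log units; beyond the scatter) and chloro gave a 5.6-fold lower number from compound 2 to compound 3 (0.75 log units; beyond the scatter) so the step away from hydrogen is not peculiar to chloro but is seen with both halogens. Nothing measured here explains why the two halogens read alike.

The compounds shown leave open whether a group other than chloro or bromo at this place, such as a methoxy group, an amine or a carboxylic acid, would read like these two halogens or like hydrogen. They also leave open where fluoro would stand among them.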